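A few compounds are considered here, and "the series" means these few. Any claim that something is new, unique, unknown or untested is made for them only; others in the source may bear on it.

Measured in a functional assay on A549 cells (Homo sapiens) for antiproliferative activity, read by MTT assay, with a stated time of 72 h; on this read-out lower numbers stand for stronger inhibition and higher numbers for weaker inhibition:

- Compound 1 `COc1ccc(OCCCON2C(N)=NC(N)=NC23CCOCC3)cc1`: 660 nM
- Compound 2 `NC1=NC2(CCOCC2)N(OCCCOc2ccc(Cl)cc2)C(N)=N1`: 360 nM
- Compound 3 `NC1=NC2(CCOCC2)N(OCCCOc2ccc(Br)cc2)C(N)=N1`: 280 nM

Compound 3 stands at the low end of these numbers, level with compound 2 within the scatter. The two steps leading to it are a 1.3-fold lower number from compound 2 to compound 3 (0.11 log units; within the scatter) and a 2.4-fold lower number from compound 1 to compound 3 (0.37 log units; beyond the scatter).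

Compound 4 `CC(C)(C)c1ccc(OCCCON2C(N)=NC(N)=NC23CCOCC3)cc1` has tert-butyl in place of bromo on an aromatic carbon. The third measured swap on that carbon is also small: a 1.8-fold lower number from compound 1 to compound 2 (0.26 log units; within the scatter). Among the compounds with values here, no measured compound carries tert-butyl, so this guide is only indirect. No step beyond the scatter is therefore expected in this assay, in either direction.

The expected change is a 1.1-fold higher number from compound 3 to compound 4 (0.06 log units; within the scatter).

Compound 4 is estimated at 320 nM, with an expected range of 140 nM to 750 nM.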

Compound 4, half-maximal inhibitory concentration: 500 nM
For compound 4 the middle estimate is 1.6-fold (0.19 log units) below the measured one; low and high end bracket the measured number.
By their numbers in this assay, from the lowest: compounds 3, 2, 4 and 1 (each within the scatter of the next, the first and the last beyond it).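

In this assay, tert-butyl, with 4 heavy atoms where bromo has 1, brings no step beyond the scatter at this aromatic carbon: a 1.8-fold higher number from compound 3 to compound 4 (0.25 log units; within the scatter), a 1.4-fold higher number from compound 2 to compound 4 (0.14 log units; within the scatter), and a 1.3-fold lower number from compound 1 to compound 4 (0.12 log units; within the scatter). Compound 4 thus sits level with both compound 1 and compound 3, although those two lie apart beyond the scatter. No measurement shown here explains these small steps. Still open, on these data alone, is whether an amine or a carboxylic acid on this carbon would give a larger step.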